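The source may report more compounds than this note shows. Statements on the series, on what has been measured and on what is new or still open speak of the compounds shown alone.

Measured so far in a functional assay on HepG2 cells (Homo sapiens) for antiproliferative activity, read by CCK-8 assay, with a stated time of 72 h; a higher number here means a weaker inhibitor, a lower number a stronger inhibitor:
- compound 1 `Cc1ccc(Nc2nc(Cl)nc3c2ncn3Cc2ccc(C(=O)Nc3ccccc3N)cc2)cc1`: 860 nM
- compound 2 `Nc1ccccc1NC(=O)c1ccc(Cn2cnc3c(Nc4cccc(Cl)c4)nc(Cl)nc32)cc1`: 9800 nM

Compound 2 has the higher of these two numbers, so it is the weaker inhibitor. Compound 3 `CN1CCN(c2nc(Cl)nc3c2ncn3Cc2ccc(C(=O)Nc3ccccc3N)cc2)CC1` carries one change from it: 4-methylpiperazin-1-yl in place of (3-chlorophenyl)amino on an aromatic carbon. Among the compounds with values here, one measured step bears on this, an 11-fold higher number from compound 1 to compound 2 (1.06 log units; beyond the scatter). That large step shows that altering this group can move the number far, but it keeps the amino nitrogen and gives no direction here. In this assay, the expected step is therefore modest and uncertain in direction: a 1.2-fold lower number from compound 2 to compound 3 (0.09 log units; within the scatter). For compound 3 the estimate is 8000 nM, with an expected range of 2000 nM to 30000 nM.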

Compound 3, half-maximal inhibitory concentration: 2010 nM
The estimate for compound 3 lay 4.0-fold (0.60 log units) above the measured number; the measured number falls inside the stated range.
By their numbers in this assay, from the lowest: compound 1; then compound 3; then compound 2.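

The same 4-methylpiperazin-1-yl group improves on (3-chlorophenyl)amino (a 4.9-fold lower number from compound 2 to compound 3 (0.69 log units; beyond the scatter)) but falls short of (4-methylphenyl)amino (a 2.3-fold higher number from compound 1 to compound 3 (0.37 log units; beyond the scatter)). This position therefore accepts a non-aromatic ring with no hydrogen-bond donor, and the direction of the step depends on which group is replaced. No measurement here accounts for these steps.

Still open, as far as these compounds go, is whether the methyl on the piperazine matters, which a plain piperazin-1-yl group would test. Also open, from the compounds shown here alone, is whether a morpholin-4-yl ring or a small dimethylamino group would match compound 1.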